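The source may report more compounds than this note shows. Statements on the series, on what has been measured and on what is new or still open speak of the compounds shown alone.

In a functional assay on U-937 cells (Homo sapiens) for cytotoxicity, read by MTT assay, with a stated time of 24 h (a higher number here means a weaker inhibitor, a lower number a stronger inhibitor), compound 1 `COc1c(Br)cc(Br)cc1Oc1ccc(Br)cc1Br` gives 34.5 ug/mL. Compound 2 `C=CCOc1c(Br)cc(Br)cc1Oc1ccc(Br)cc1Br`, which in this assay gives 29 ug/mL, holds the lowest of the two numbers, although the step of a 1.2-fold lower number from compound 1 to compound 2 (0.08 log units; within the scatter) does not separate the two compounds. Compound 3 `OCCOc1c(Br)cc(Br)cc1Oc1ccc(Br)cc1Br` has not yet been measured in this assay. Its change from compound 2 is hydroxymethyl in place of vinyl on a saturated chain carbon bound to an oxygen on an aromatic ring. For the measured compounds named here, the one measured step, a 1.2-fold lower number from compound 1 to compound 2 (0.08 log units; within the scatter), touches the same place, a saturated chain carbon bound to an oxygen on an aromatic ring, but it put vinyl in place of hydrogen rather than hydroxymethyl in place of vinyl, and it stayed within the scatter. Going by the values given here, no measured pair shows a hydroxymethyl entering anywhere, so the data give no sign of a step beyond the scatter in either direction. Compound 3 is therefore expected to give 30 ug/mL, with a range from 15 ug/mL to 60 ug/mL. That expectation amounts to a step of a 1.0-fold higher number from compound 2 to compound 3 (0.01 log units; within the scatter).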

Compound 3, half-maximal inhibitory concentration: 34.5 ug/mL
For compound 3 the middle estimate is 1.2-fold (0.06 log units) below the measured one; measured number inside the range.
By their numbers in this assay, from the lowest: compounds 2, 1 and 3 (each within the scatter of the next).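

Hydroxymethyl in place of vinyl gives a 1.2-fold higher number from compound 2 to compound 3 (0.08 log units; within the scatter) in this assay, and hydroxymethyl in place of hydrogen gives no change at the digits printed from compound 1 to compound 3 (within the scatter) at the same saturated chain carbon bound to an oxygen on an aromatic ring. The earlier step covered only the arrival of vinyl, whereas these steps show that a group with a hydrogen-bond donor and a hydrogen-bond acceptor also leaves the number within the scatter, so allyl and 2-hydroxyethyl cannot be told apart here. No measurement offers an explanation for this lack of separation.

From the compounds shown here alone, whether an amine, a carboxylic acid or a longer chain at this place would give a step beyond the scatter remains open. The compounds shown also leave open whether any change at this place, rather than elsewhere on the shared core, can shift the number in this assay at all.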